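Swapping the methoxy pyridine for a cyano pyridine

This account rests on a few compounds, and the source may have more. Where it says the series, first, only, none or still open, it means among the compounds named here.

Measured so far:
compound 1, `FC(F)(F)Oc1ccc(-c2nc3cnc(Nc4ccccn4)cc3[nH]2)cc1`, 61%
compound 2, `COc1ccnc(Nc2cc3[nH]c(-c4cccc(C(F)(F)F)c4)nc3cn2)c1`, 71%
compound 3, `Fc1ccc(Nc2cc3[nH]c(-c4cccc(C(F)(F)F)c4)nc3cn2)nc1`, 42%

The three compounds share one core and differ in the group attached to the nitrogen on the aromatic ring. In an ADME assay on microsomes from liver (Rattus norvegicus) for metabolic stability, read by LC-MS, with a stated time of 30 min, tested at 0.1 uM (a higher number here means that more of the compound is left, a lower number that less of the compound is left), compound 2 gives the highest of the three numbers. Compound 1 sits close to it, a gap that stays within the scatter, so the two cannot be ranked against each other. Compound 3 lies clearly lower: a number 29 percentage points lower from compound 2 to compound 3 (beyond the scatter), a drop beyond the scatter.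

Compound 4, `N#Cc1ccc(Nc2cc3[nH]c(-c4cccc(C(F)(F)F)c4)nc3cn2)nc1`, has not yet been measured in this assay. It differs from compound 2 in one place: 5-cyanopyridin-2-yl in place of 4-methoxypyridin-2-yl on a nitrogen on an aromatic ring.

Among the measured compounds shown here, only one measured step bears on this change, the move from compound 2 to compound 3, where the same 4-methoxypyridin-2-yl group was exchanged for a different pyridine and the number fell by a modest amount beyond the scatter. A single step of that kind suggests that trading the 4-methoxypyridin-2-yl group away costs stability, so for compound 4 a drop of similar size is expected, a number 23 percentage points lower from compound 2 to compound 4 (beyond the scatter). The estimate for compound 4 in this assay is 48%, with a range from 28% to 68%.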

Compound 4, percent of the compound remaining: 49%
Compound 4: middle estimate off by 1 percentage points, on the low side, and the stated range covers the measured number.
By their numbers in this assay, from the lowest: compounds 3 and 4 (each within the scatter of the next); then compounds 1 and 2 (each within the scatter of the next).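

The drop seen with 5-fluoropyridin-2-yl now appears with a second group: in this assay, moving to 5-cyanopyridin-2-yl gives a number 22 percentage points lower from compound 2 to compound 4 (beyond the scatter), so among these compounds the loss is not tied to fluoro alone. Exchanging only the small group on that pyridine, cyano in place of fluoro on an aromatic carbon, gives a number 7 percentage points higher from compound 3 to compound 4 (within the scatter), which means that the two groups cannot be told apart here, and both compound 3 and compound 4 stand clearly apart from compound 2. Nothing measured here explains why these replacements differ from 4-methoxypyridin-2-yl.

The compounds shown leave open whether the difference comes from losing the methoxy group itself or from where the group sits on the pyridine, since both change together in each step. A direct comparison with 5-methoxypyridin-2-yl on the same core would separate the two, and a 5-aminopyridin-2-yl group would show whether the result holds beyond fluoro and cyano.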